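Moving from a methylsulfonyl toward an imidazolylmethylsulfonyl group

The source may report more compounds than this note shows. Statements on the series, on what has been measured and on what is new or still open speak of the compounds shown alone.

Of the compounds shown here, three have been tested so far in an assay on HEK293 cells for inhibition of prostaglandin E2 receptor EP4 subtype (Rattus norvegicus) (a higher number here means a weaker inhibitor, a lower number a stronger inhibitor), and none of them gave a number. Compound 1 `CCCCC(O)c1ccc(CN(CCCCCCC(=O)O)S(C)(=O)=O)cc1` reached only the limit of the assay in this assay, recorded as > 3200 nM. Compound 2 `CCCCc1ccc(CN(Cc2ccccc2OCC(=O)O)S(C)(=O)=O)cc1` likewise stopped at a limit, with > 3200 nM in this assay. Compound 3 `CC(C)(C)c1ccc(CN(Cc2cccc(OCC(=O)O)c2)S(C)(=O)=O)cc1` stands at a limit as well, > 3200 nM in this assay. All three values therefore sit at the same point, as summed up in the limit of > 3200 nM in this assay, at which 3 of the 3 values shown sit, and no ranking among them can be drawn.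

Compound 4 `Cn1ccnc1CS(=O)(=O)N(Cc1ccc(C(C)(C)C)cc1)Cc1cccc(OCC(=O)O)c1` is built from compound 3 by one change: 1-methyl-1H-imidazol-2-yl in place of hydrogen on a saturated chain carbon bound to a sulfonyl sulfur. Going by the values given here, no step between two measured compounds exists here, so the direction of this change cannot be read from the data; it has to be estimated. Because compound 3 gave only a limit at > 3200 nM, any real number for compound 4 would already mark a gain, while another limit remains a fair possibility. The expected step from compound 3 to compound 4 in this assay is an at least 2.1-fold lower number from compound 3 to compound 4 (0.32 log units; beyond the scatter), a change somewhat beyond the usual scatter toward stronger inhibition. Compound 4 is estimated at 1500 nM in this assay, with a range from 150 nM to 10000 nM.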

Compound 4, half-maximal inhibitory concentration: > 3200 nM
Compound 4: a limit, no number; the forecaster's own chance of this, stated with the estimate: 50%; middle value at least 2.1-fold (0.32 log units) from the limit.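

In this assay compound 4 gives > 3200 nM as a limit and not a number. Compound 3 also stopped at a limit, so no step can be read between compound 3 and compound 4. All four compounds share one point: the limit of > 3200 nM in this assay, at which 4 of the 4 values shown sit. Still open, on these data alone, is whether 1-methyl-1H-imidazol-2-yl in place of hydrogen changes inhibition at all, and how these four compounds rank.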